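Thiophene to 3-nitrophenyl swap at the ring carbon: solubility

The source may report more compounds than this note shows. Statements on the series, on what has been measured and on what is new or still open speak of the compounds shown alone.

Measured compounds, solubility in a physicochemical assay for solubility, in phosphate buffer, at pH 7.4; a higher number here means a more soluble compound, a lower number a less soluble compound:
- compound 1, `CCOC(=O)c1c(-c2ccc(OC)cc2)[nH]c2cccc(OC)c2c1=O`: > 100000 nM (a limit of the assay, not a number)
- compound 2, `CCOC(=O)c1c(-c2cccs2)[nH]c2cc(OC)ccc2c1=O`: > 100000 nM (a limit of the assay, not a number)
- compound 3, `CCOC(=O)c1c(-c2cccc(OC)c2)[nH]c2cccc(OC)c2c1=O`: > 100000 nM (a limit of the assay, not a number)

Compound 2 sits at the limit of this assay, and so do the two other measured values; the series is summarised by the limit of > 100000 nM in this assay, at which 3 of the 3 values shown sit. Among the compounds with values here, the only single-point step among the measured compounds, a step that the two limits leave unreadable from compound 1 to compound 3, is unreadable for the same reason, so no measured step gives a size that can be carried over.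

Compound 4, `CCOC(=O)c1c(-c2cccc([N+](=O)[O-])c2)[nH]c2cc(OC)ccc2c1=O`, differs from compound 2 as follows. 3-nitrophenyl in place of thiophen-2-yl on an aromatic carbon

Within the data shown here, no measured step bears on this change, and nothing in the three limits speaks for or against a shift in this assay in either direction. The expectation for compound 4 is therefore anchored at the limit where compound 2 stands, with the step of an at least 1.4-fold lower number from compound 2 to compound 4 (0.15 log units; that floor lies within the scatter) expected to be small or not readable at all. Compound 4 is estimated at 70000 nM, in the range 15000 nM to 100000 nM, and a further limit-only read-out is considered likely.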

Compound 4, solubility: 13000 nM
Estimate against measurement, compound 4: 5.4-fold (0.73 log units) above; measured number outside the range, below it.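

In this assay, 3-nitrophenyl in place of thiophen-2-yl on the aromatic carbon next to the ring nitrogen, ortho to the ethoxycarbonyl group, gives an at least 7.6-fold lower number from compound 2 to compound 4 (0.88 log units; beyond the scatter), so a change at this position can be read in this series once a value comes off the limit. On these data alone, compound 2 stands at a limit of the assay and not at a number, so this step is a floor and its true size remains unknown. Compound 4 carries the only value shown that is not a limit, which makes it the single usable reference point for further changes at this carbon: the limit of > 100000 nM in this assay, at which 3 of the 4 values shown sit.

The compounds shown do not separate the contribution of the nitro group from that of the phenyl ring itself, and a plain phenyl on the core of compound 2 would be the comparison that divides the step between the two. As far as these compounds go, how an amine or a carboxylic acid in place of the nitro group would read in this assay also stays open, as does whether any such result would carry over to the core of compound 1.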